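Compound 3: 2-methylphenyl in place of 1H-indol-4-yl

The source may report more compounds than this note shows. Statements on the series, on what has been measured and on what is new or still open speak of the compounds shown alone.

In a physicochemical assay for lipophilicity, at pH 7.4 (on this read-out higher numbers stand for higher lipophilicity and lower numbers for lower lipophilicity), compound 2 (`CNC(=O)c1cc(C(=O)N[C@H]2[C@@H]3COC[C@@H]32)cc2c1OC[C@H]2c1cccc2[nH]ccc12`) gives 3.1, the lower of the two numbers, and compound 1 (`CNC(=O)c1cc(C(=O)NC2CC2)cc2c1OC[C@H]2c1cccc2[nH]ccc12`) gives 3.5. Among the compounds with values here, compound 3 (`CNC(=O)c1cc(C(=O)N[C@H]2[C@@H]3COC[C@@H]32)cc2c1OC[C@H]2c1ccccc1C`) has no measurement yet. The change is 2-methylphenyl in place of 1H-indol-4-yl on a saturated ring carbon, in words 2-methylphenyl in place of 1H-indol-4-yl on a saturated ring carbon. Within the data shown here, the only measured step, a number 0.40 log units lower from compound 1 to compound 2 (beyond the scatter), is a modest one on an amide-type nitrogen, a different place, so it offers scale and no direct precedent. A small rise is expected, possibly not beyond the scatter: a number 0.20 log units higher from compound 2 to compound 3 (within the scatter). For compound 3 the estimated value is 3.3, with an expected range of 2.9 to 3.7.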

Compound 3, distribution coefficient: 4
Compound 3: the middle estimate sits 0.70 log units below what was measured, outside the stated range (above it).
By their numbers in this assay, from the lowest: compound 2; then compound 1; then compound 3.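

In this assay, the saturated ring carbon two ring bonds from the ring oxygen proves sensitive to the aryl group: 2-methylphenyl in place of 1H-indol-4-yl gives a number 0.90 log units higher from compound 2 to compound 3 (beyond the scatter). This step runs opposite to, and is larger than, the change on the amide-type nitrogen, a number 0.40 log units lower from compound 1 to compound 2 (beyond the scatter). No supporting data bear on the origin of the rise.

The compounds shown do not separate the contribution of the methyl from that of the aryl ring, leaving plain phenyl or 2-methoxyphenyl at this carbon as open cases. From the compounds shown here alone, whether the step holds with the amide group of compound 1 also remains open.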